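The compounds below may be only part of what the source reports. "The series", "measured", "known", "first", "only" and "open" are said of these compounds alone.

Measured so far in a functional assay on PC-3 cells (Homo sapiens) for antiproliferative activity, read by MTT assay; a lower number here means a stronger inhibitor, a higher number a weaker inhibitor:
- compound 1 `CNC(=O)c1ccc(Oc2cccc(NC(=S)Nc3ccc(Cl)cc3)c2)nc1`: 28400 nM
- compound 2 `CNC(=O)c1ccc(Oc2cccc(NC(=S)Nc3ccc(F)c(F)c3)c2)nc1`: 23100 nM
- compound 3 `CNC(=O)c1ccc(Oc2cccc(NC(=S)Nc3ccc(Cl)cc3Cl)c2)nc1`: 19300 nM

Compound 1 gives the highest of the three numbers in this assay, though its separation from the other two is small: a 1.2-fold lower number from compound 1 to compound 2 (0.09 log units; within the scatter) and a 1.5-fold lower number from compound 1 to compound 3 (0.17 log units; within the scatter) both fall within the scatter, as does a 1.2-fold lower number from compound 2 to compound 3 (0.08 log units; within the scatter). On these three compounds the ring on the thiourea nitrogen has tolerated halogen exchange without any step that can be told apart from repeat measurement.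

Compound 4 `CNC(=O)c1ccc(Oc2cccc(NC(=S)Nc3ccc(Cl)c(C(F)(F)F)c3)c2)nc1` is the next member. Relative to compound 1 the change is trifluoromethyl in place of hydrogen on an aromatic carbon. For the measured compounds named here, the one measured step that also adds a substituent to that ring is a 1.5-fold lower number from compound 1 to compound 3 (0.17 log units; within the scatter), and it stayed inside the scatter; the other two steps, which swap halogen patterns on the same ring, did likewise. Nothing measured here points to a trifluoromethyl group moving the number by more than the other ring changes did, so the expectation for compound 4 in this assay is a step of about a 1.4-fold lower number from compound 1 to compound 4 (0.15 log units; within the scatter), that is, no change that clearly exceeds the scatter, with a slight lean toward a lower number. The estimate for compound 4 is 20000 nM, with a range from 8000 nM to 45000 nM.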

Compound 4, half-maximal inhibitory concentration: 1980 nM
The estimate for compound 4 lay 10-fold (1.00 log units) above the measured number; measured number below the stated range.
By their numbers in this assay, from the lowest: compound 4; then compounds 3, 2 and 1 (each within the scatter of the next).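

In this assay, trifluoromethyl in place of hydrogen on an aromatic carbon, ortho to a chloro group, gives a 14-fold lower number from compound 1 to compound 4 (1.16 log units; beyond the scatter), the one listed step in the series that lies beyond the scatter. For the compounds shown here, the ring on the thiourea nitrogen therefore does respond to substitution, which the earlier compounds did not show: adding a chloro group gave only a 1.5-fold lower number from compound 1 to compound 3 (0.17 log units; within the scatter), and the change of halogen pattern gave only a 1.2-fold lower number from compound 1 to compound 2 (0.09 log units; within the scatter), both within the scatter. No measurement in hand bears on what lies behind the step, so the size of the change stands as an observation only.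

The compounds shown leave open whether the step belongs to trifluoromethyl itself or would also appear with a methyl, a nitrile or a methoxy group at the same place on the ring. They also leave open whether the chloro group is needed for the effect, a question that a match for compound 4 carrying hydrogen or fluoro in place of that chloro group would address.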